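Turning one stereocentre in the amide side chain

The source may hold more compounds than are shown below. What is called first, only, known or untested is meant among the compounds shown, and "the series" means these compounds.

Compound 1 `CCn1c(C(=O)NCCC(=O)OC)ccc1C(CC)(CC)c1ccc(OCS(=O)(=O)c2ccccc2)c(C)c1` gives > 50000 nM
Compound 2 `CCn1c(C(=O)N[C@H](CO)C(C)C)ccc1C(CC)(CC)c1ccc(OCS(=O)(=O)c2ccccc2)c(C)c1` gives 7720 nM

In a functional assay on BXPC-3 cells (Homo sapiens) for antiproliferative activity, read by MTT assay, with a stated time of 24 h (on this read-out lower numbers stand for stronger inhibition and higher numbers for weaker inhibition), compound 1 reaches only a limit (> 50000 nM) and not a true number. For the measured compounds named here, compound 2 therefore holds the only true number so far (7720 nM). Compound 3 `CCn1c(C(=O)N[C@@H](CO)C(C)C)ccc1C(CC)(CC)c1ccc(OCS(=O)(=O)c2ccccc2)c(C)c1` is its mirror-image partner at one centre, and the comparison reads: the two compounds have the same atoms and bonds and differ only in configuration as drawn: 1 of 1 stereo elements differ; a stereocentre at a saturated chain carbon is drawn S in compound 2 and R in compound 3. Going by the values given here, the one measured step, an at least 6.4-fold lower number from compound 1 to compound 2 (0.81 log units; beyond the scatter), replaced a whole group on the amide nitrogen, so it shows that this side chain can matter but does not test configuration. Among the compounds with values here, no measured pair isolates a change of configuration. The expected step is therefore a 1.2-fold higher number from compound 2 to compound 3 (0.07 log units; within the scatter), with real uncertainty. For compound 3 the estimated value is 9000 nM (expected range 3000 nM to 30000 nM).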

Compound 3, half-maximal inhibitory concentration: 13200 nM
Estimate against measurement, compound 3: 1.5-fold (0.17 log units) below; the measured number falls inside the stated range.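

In this assay the step on reversing the one stereocentre of the side chain is a 1.7-fold higher number from compound 2 to compound 3 (0.23 log units; within the scatter) and so the two drawn configurations cannot be told apart here. The 1-(hydroxymethyl)-2-methylpropyl group also keeps its edge over 2-(methoxycarbonyl)ethyl in the second configuration, with an at least 3.7-fold lower number from compound 1 to compound 3 (0.57 log units; beyond the scatter) and so that edge does not rest on one mirror form alone. The value of compound 1 in this comparison is a limit and not a true number: the limit of > 50000 nM in this assay, at which 1 of the 3 values shown sits.

The compounds shown leave open which part of the 1-(hydroxymethyl)-2-methylpropyl group matters, the hydroxymethyl or the branched end. They also leave open how a carboxylic acid, an amine or a longer chain would fare on the same amide nitrogen.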